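The compounds below may be only part of what the source reports. "The series", "measured", "known", "first", "only" and "open" are said of these compounds alone.

In a functional assay on the whole organism (strain Jcl:SD) for inhibition, with Rattus norvegicus as the target, with stated times of 3 min and 3 h, at a dose of 1 mg/kg by the intravenous route (a higher number here means more inhibition at the dose given (going by the name of the read-out), a lower number less inhibition), compound 1 `CNCc1cc(-c2cccnc2C#N)n(S(=O)(=O)c2cccnc2)c1` gives 48%, while compound 2 `CNCc1cc(-c2cccnc2C)n(S(=O)(=O)c2cccnc2)c1` gives -41%, the lower of the two numbers measured. Going by the values given here, the single measured step, a number 89 percentage points lower from compound 1 to compound 2 (beyond the scatter), is large and bears only loosely on the change at hand. Among the compounds with values here, compound 3 `CNCc1cc(-c2ccncc2F)n(S(=O)(=O)c2cccnc2)c1` differs from compound 2 by 3-fluoropyridin-4-yl in place of 2-methylpyridin-3-yl on an aromatic carbon, so compound 3 carries neither the nitrile of compound 1 nor the methyl of compound 2, and no measured step involves a fluorine. A modest rise is expected, a number 51 percentage points higher from compound 2 to compound 3 (beyond the scatter), with wide uncertainty. Compound 3 is therefore estimated at 10%, between -40% and 50%.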

Compound 3, a percentage reported as inhibition, in the whole organism at one dose (the size of the read-out at that dose, not a potency): 48%
Beside the measured number, compound 3's estimate is 38 percentage points below it; the measured number falls inside the stated range.
By their numbers in this assay, from the lowest: compound 2; then compounds 1 and 3 (each within the scatter of the next).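

In this assay, the step to the 3-fluoropyridin-4-yl group is a number 89 percentage points higher from compound 2 to compound 3 (beyond the scatter), so the low value of compound 2 is not shared by every replacement at this place on the core. The nitrile is also not needed for this level of inhibition, with no change at the digits printed from compound 1 to compound 3 (within the scatter). No data here explain either step.

The ring changes in two ways between compound 2 and compound 3, so the roles of the fluorine and of the ring nitrogen's location remain unseparated. A chlorine in place of the fluorine, or a pyridine ring carrying no substituent, could help to tell them apart.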